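A few compounds are considered here, and "the series" means these few. Any claim that something is new, unique, unknown or untested is made for them only; others in the source may bear on it.

Measured compounds:
compound 1 `CN(C)CCn1cnnc1-c1cc(Oc2ccc(NC(=O)N/N=C/c3cccc(O)c3)cc2F)ccn1` — > 100000 nM
compound 2 `CN(C)CCn1cnnc1-c1cc(Oc2ccc(NC(=O)N/N=C/c3cc(Br)c(O)c(Br)c3)cc2F)ccn1` — > 100000 nM
compound 3 `CN(C)CCn1cnnc1-c1cc(Oc2ccc(NC(=O)N/N=C/c3c[nH]c4ccccc34)cc2F)ccn1` — 820 nM

In a functional assay on A549 cells (Homo sapiens) for cytotoxicity, read by MTT assay, with a stated time of 72 h (on this read-out higher numbers stand for weaker inhibition and lower numbers for stronger inhibition), compound 1 reaches only a limit of the assay, > 100000 nM. Compound 2 likewise gives a limit, > 100000 nM. Going by the values given here, compound 3 is the sole compound with a number, 820 nM, and so it stands as the only readable point among the three. The other two values are limits of the assay. The step of an at least 120-fold lower number from compound 1 to compound 3 (2.08 log units; beyond the scatter) and the step of an at least 120-fold lower number from compound 2 to compound 3 (2.08 log units; beyond the scatter) are both large and beyond the scatter, whereas a step that the two limits leave unreadable from compound 1 to compound 2 cannot be read, since both of its values sit at the limit of > 100000 nM in this assay, at which 2 of the 3 values shown sit.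

Compound 4 `CN(C)CCn1cnnc1-c1cc(Oc2ccc(NC(=O)N/N=C/c3c(Cl)cccc3Cl)cc2F)ccn1` has not yet been measured. Its difference from compound 3 is this: 2,6-dichlorophenyl in place of 1H-indol-3-yl on a carbon with a double bond to nitrogen. No measured step involves a 2,6-dichlorophenyl; the two steps shown describe only the gain from the two hydroxyphenyls to the 1H-indol-3-yl. Compound 4 carries a six-membered aromatic ring of carbon only, as compounds 1 and 2 do, but it lacks the hydroxy group they bear, so their limits are a loose guide rather than a direct comparison. The writer therefore expects a step of a 12-fold higher number from compound 3 to compound 4 (1.09 log units; beyond the scatter), toward a higher number, with a real chance that only a limit is reported. Compound 4 is estimated at 10000 nM, within 1500 nM to 100000 nM.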

Compound 4, half-maximal inhibitory concentration: 1410 nM
Compound 4: the middle estimate sits 7.1-fold (0.85 log units) above what was measured; the whole stated range lies above it.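

In this assay, replacing the 1H-indol-3-yl on the carbon with a double bond to nitrogen gives a 1.7-fold higher number from compound 3 to compound 4 (0.24 log units; within the scatter), so the fused five-membered ring and its hydrogen-bond donor are not needed for a measurable value at this position, as 2,6-dichlorophenyl, a single six-membered aromatic ring of carbon only, serves there as well. Going by these compounds alone, the earlier compounds could not show this, since the only number among them belonged to the indole, whereas the new comparisons give an at least 70-fold lower number from compound 2 to compound 4 (1.85 log units; beyond the scatter) and an at least 70-fold lower number from compound 1 to compound 4 (1.85 log units; beyond the scatter), both large, which shows that a six-membered carbon ring at this place does not by itself lead to the loss seen with the hydroxyphenyls. Compounds 1 and 2, the two that carry a hydroxy group, remain limits of the assay rather than numbers: the limit of > 100000 nM in this assay, at which 2 of the 4 values shown sit.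

As far as these compounds go, what stays open is whether the gain of compound 4 over compounds 1 and 2 comes from the absence of the hydroxy group or from the presence of the two chlorine atoms. A plain phenyl or a methoxyphenyl at this place would help separate these two readings, and all of this rests on a single cell line.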